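Replacing the Methyl on the Ring Nitrogen with Azetidinyl

This account rests on a few compounds, and the source may have more. Where it says the series, first, only, none or still open, it means among the compounds named here.

Three compounds sharing one core differ only in the group carried on an aromatic nitrogen. In a functional assay on CHO cells for antagonist activity at C-C chemokine receptor type 4 (Homo sapiens), read by radioligand binding and GTPgammaS binding (on this read-out higher numbers stand for weaker inhibition and lower numbers for stronger inhibition), compound 1 `COc1cc2c(cc1NS(=O)(=O)c1cccc(Cl)c1Cl)[nH]c(=O)n2C` gives 200 nM, the lowest of the three numbers. Compound 2 `COc1cc2c(cc1NS(=O)(=O)c1cccc(Cl)c1Cl)[nH]c(=O)n2C(C)C` gives 1000 nM, and compound 3 `COc1cc2c(cc1NS(=O)(=O)c1cccc(Cl)c1Cl)[nH]c(=O)n2C(CO)CO` gives 1580 nM. Both enlargements of the methyl cost potency: a 5.0-fold higher number from compound 1 to compound 2 (0.70 log units; beyond the scatter) and a 7.9-fold higher number from compound 1 to compound 3 (0.90 log units; beyond the scatter), while a 1.6-fold higher number from compound 2 to compound 3 (0.20 log units; within the scatter) shows the two larger groups close to each other.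

Compound 4 `COc1cc2c(cc1NS(=O)(=O)c1cccc(Cl)c1Cl)[nH]c(=O)n2C1CNC1` takes the same starting point and makes the change (azetidin-3-yl in place of methyl on an aromatic nitrogen). The new group resembles isopropyl in carrying three carbons on the attachment point, but closes them into a small ring that also holds a nitrogen with a hydrogen on it.

The two measured steps that bear on this change, from compound 1 to compound 2 and from compound 1 to compound 3, both moved the number upward by a modest margin beyond the scatter, and neither a branched group nor a hydroxyl-bearing one escaped that cost. The expectation for compound 4 is therefore a step in the same direction, of about a 4.5-fold higher number from compound 1 to compound 4 (0.65 log units; beyond the scatter), in this assay. Compound 4 is accordingly estimated at 900 nM, with a likely range from 350 nM to 2500 nM.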

Compound 4, half-maximal inhibitory concentration: 398 nM
Beside the measured number, compound 4's estimate is 2.3-fold (0.35 log units) above it; the measured number falls inside the stated range.
By their numbers in this assay, from the lowest: compounds 1 and 4 (each within the scatter of the next); then compounds 2 and 3 (each within the scatter of the next).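

In this assay, the aromatic nitrogen can carry a group larger than methyl with no cost beyond the scatter, as azetidin-3-yl leaves compound 4 not separable from compound 1 (a 2.0-fold higher number from compound 1 to compound 4 (0.30 log units; within the scatter)). Azetidin-3-yl also stands apart from the two other large groups, with clear gaps to the isopropyl of compound 2 (a 2.5-fold lower number from compound 2 to compound 4 (0.40 log units; beyond the scatter)) and to the 2-hydroxy-1-(hydroxymethyl)ethyl of compound 3 (a 4.0-fold lower number from compound 3 to compound 4 (0.60 log units; beyond the scatter)). Enlarging the methyl therefore does not always raise the number beyond the scatter: compounds 2 and 3 show that cost, and compound 4 goes against it.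

No measurement at hand says what lies behind the gap between compound 4 and compounds 2 and 3. The four compounds cannot separate the closed ring from the ring nitrogen with its hydrogen, a question that cyclobutyl, the same ring with carbon in place of that nitrogen, and an azetidin-3-yl with a methyl on its nitrogen could help to settle.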